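The source may hold more compounds than are shown below. What is called first, only, known or untested is meant among the compounds shown, and "the series" means these compounds.

Among the measured compounds shown here, in a functional assay on MCF7 cells (Homo sapiens) for inhibition, read by sulforhodamine B assay, with a stated time of 48 h, tested at 50 uM (a higher number here means more inhibition of growth at the concentration tested, a lower number less inhibition of growth), compound 1 `COc1cc2c(cc1CC=C(C)C)C(=O)C[C@@H](c1ccc(Oc3ccc(F)cc3)cc1)O2` gives 37%, the lower of the two numbers measured so far. Compound 2 `COc1cc2c(cc1CC=C(C)C)/C(=N/O)C[C@@H](c1ccc(O)cc1)O2` differs from compound 1 in several places. In this assay compound 2 gives 93%. Compound 3 `COc1cc2c(cc1CC=C(C)C)C(=O)C[C@@H](c1ccc(Oc3ccc(Br)cc3)cc1)O2` has not yet been measured; it differs from compound 1 by bromo in place of fluoro on an aromatic carbon. For the measured compounds named here, no measured pair shows this change alone, so the expected step of a number 5 percentage points higher from compound 1 to compound 3 (within the scatter) is small, at most a modest rise and possibly none beyond the scatter. Compound 3 is estimated to give 42% in this assay, with a range from 25% to 60%.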

Compound 3, percent growth inhibition at one concentration: 68%
Beside the measured number, compound 3's estimate is 26 percentage points below it; the measured number lies above the stated range.
By their numbers in this assay, from the lowest: compound 1; then compound 3; then compound 2.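

In this assay, among the compounds shown here, bromo in place of fluoro on an aromatic carbon gives a number 31 percentage points higher from compound 1 to compound 3 (beyond the scatter), the first step that isolates a single change. It shows that growth inhibition responds to the atom at this position, para to a large group, even though the swap leaves the ring and the count of hydrogen-bond donors and acceptors untouched. Nothing available explains why this change has this effect.

Going by these compounds, whether chloro, iodo or an amine at this position would follow the same trend remains open. So does whether removing the 4-bromophenoxy group's halogen altogether would lower inhibition.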